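Pyridin-2-yl in place of the bicyclic amide substituent

A few compounds are considered here, and "the series" means these few. Any claim that something is new, unique, unknown or untested is made for them only; others in the source may bear on it.

Compound 1 `O=C(Cn1nnc(-c2ccccc2)n1)NC1CC2CCC1C2`: 1980 nM
Compound 2 `Cc1cc(NC(=O)Cn2nnc(-c3ccccc3)n2)n(C(C)C)n1`: 556 nM

In an assay on HEK293 cells for activation of Kir3.1/Kir3.2 (Homo sapiens), read by thallium flux (on this read-out lower numbers stand for an effect already at smaller amounts and higher numbers for an effect only at larger amounts of compound), compound 1 gives the highest of the two numbers; compound 2 gives a lower number, and that gap lies beyond the scatter. Compound 3 `O=C(Cn1nnc(-c2ccccc2)n1)Nc1ccccn1` is not yet measured. Compared with compound 1 it carries a group of 6 heavy atoms (5 carbon, 1 nitrogen; one six-membered aromatic ring with 1 hetero atom) in place of a group of 7 heavy atoms (7 carbon; 2 five-membered non-aromatic rings of carbon only), on an amide-type nitrogen. Going by the values given here, with only two measured compounds, no step of this kind is known. Compound 2 suggests that an aromatic heterocycle on the amide nitrogen gives a lower number in this assay, so a moderate step downward is expected. Compound 3 is therefore estimated at 700 nM, within 200 nM to 2500 nM, a change of a 2.8-fold lower number from compound 1 to compound 3 (0.45 log units; beyond the scatter) expected.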

Compound 3, half-maximal effective concentration: "not active" (no number reported)
For compound 3 the study gives words and no number; the estimate stays without a comparison.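

In this assay, going by these compounds alone, compound 3 is reported as not active, with no number, so no step from compound 1 to compound 3 can be read. No measurement shown here accounts for this result. The compounds shown leave open how other aromatic rings on the amide-type nitrogen would behave.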